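Allyl to phenyl on the triazole nitrogen: estimate for compound 4

This account rests on a few compounds, and the source may have more. Where it says the series, first, only, none or still open, it means among the compounds named here.

Measured compounds:
compound 1 `COc1cc(-c2nnc(SCC(=O)Nc3ccc(/C(C)=N/O)cc3)n2-c2ccccc2)cc(OC)c1OC`: 66%
compound 2 `C=CCn1c(SCC(=O)Nc2ccc(C(C)=O)cc2)nnc1-c1ccc(OC)cc1`: 52%
compound 3 `C=CCn1c(SCC(=O)Nc2ccc(/C(C)=N/O)cc2)nnc1-c1cc(OC)c(OC)c(OC)c1`: 62%

All three were tested in a functional assay on the whole organism (strain albino) for inhibition, with Rattus norvegicus as the target, read by paw edema, with stated times of 30 min and 3 h, at a dose of 0.28 mmol/kg by the oral route; on this read-out lower numbers stand for less inhibition and higher numbers for more inhibition at the one dose given (going by the name of the read-out). Compound 1 reaches 66%, compound 3 gives 62%, and compound 2 gives 52%, the lowest of the three; its gap to compound 1 lies beyond the scatter, its gap to compound 3 does not.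

Compounds 1 and 3 differ in one place: phenyl in place of allyl on an aromatic nitrogen. That step gave a number 4 percentage points higher from compound 3 to compound 1 (within the scatter).

Compound 4 `COc1ccc(-c2nnc(SCC(=O)Nc3ccc(C(C)=O)cc3)n2-c2ccccc2)cc1` is not yet measured. It relates to compound 2 through (phenyl in place of allyl on an aromatic nitrogen). This is the same kind of change as the step from compound 3 to compound 1, not the same: in compound 2 the place is next to the ring atom that bears a 4-methoxyphenyl group and next to the ring atom that bears a large group, whereas in compound 3 it is next to two ring atoms that each bear a large group. The difference between the cores of compound 2 and compound 3 is not broken down here.

Resting on compound 2 at 52% and on the earlier step of a number 4 percentage points higher from compound 3 to compound 1 (within the scatter), the step from compound 2 to compound 4 is expected to be a number 4 percentage points higher from compound 2 to compound 4 (within the scatter), again within the scatter. Compound 4 is therefore estimated at 56%, with a likely range from 44% to 68%.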

Compound 4, a percentage reported as inhibition, in the whole organism at one dose (the size of the read-out at that dose, not a potency): 58%
Compound 4: the middle estimate sits 2 percentage points below what was measured; measured number inside the range.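

In this assay, phenyl in place of allyl on the aromatic nitrogen gives a number 6 percentage points higher from compound 2 to compound 4 (within the scatter), and the step reads alike on the two cores: the same change on two cores in this assay, a number 4 percentage points higher (within the scatter) from compound 3 to compound 1 and a number 6 percentage points higher (within the scatter) from compound 2 to compound 4, 2 percentage points apart, within the scatter of two such steps

The change therefore carries from the core of compound 3 to the core of compound 2 with no difference that can be told apart, and that is as far as two pairs reach. Each step lies within the scatter on its own, so neither pair shows that phenyl gives more inhibition than allyl at this place, and neither shows that the change would carry to a third core.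

The compounds shown place only allyl and phenyl on this nitrogen, leaving open how a saturated propyl chain, a benzyl group or a chain ending in an amine would read there. Also open, as far as these compounds go, is whether the step would hold with a carboxylic acid in place of the 4-methoxyphenyl group.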